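The compounds below may be only part of what the source reports. "The series", "measured", "known", "first", "only" and "open" are said of these compounds alone.

Among the measured compounds shown here, in a functional assay on NCI-H460 cells (Homo sapiens) for antiproliferative activity, with a stated time of 72 h (on this read-out higher numbers stand for weaker inhibition and lower numbers for stronger inhibition), compound 1 (`C=CC[C@H]1C[C@]2([C@@H](C)Cc3ccc(OC)cc3)OCOC2=CC1=O`) gives 90 nM, the only exact number available. Compound 2 (`C=CC[C@H]1C[C@]2([C@@H](C)Cc3ccc(O)cc3)OCOC2=CC1=O`) reads > 20000 nM, and this value is a limit of the assay. Compound 3 (`C=CC[C@H]1C[C@]2([C@@H](C)Cc3ccc(OC)c(C#N)c3)OCOC2=CC1=O`) keeps the methoxy group of compound 1 and carries cyano in place of hydrogen on an aromatic carbon, ortho to that methoxy group: cyano in place of hydrogen on an aromatic carbon. For the measured compounds named here, only one measured step bears on this change, and only indirectly. In an at least 220-fold higher number from compound 1 to compound 2 (2.34 log units; beyond the scatter), a large step beyond the scatter, hydrogen replaces methyl on an oxygen on the same aromatic ring. That step for compound 2 gives reason to expect some loss in this assay, though a much smaller one, since the methoxy group stays in place. The expected change is a 2.8-fold higher number from compound 1 to compound 3 (0.44 log units; beyond the scatter), towards weaker inhibition. Compound 3 is estimated at 250 nM, with an expected range from 50 nM to 2500 nM.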

Compound 3, half-maximal inhibitory concentration: 340 nM
Compound 3: the middle estimate sits 1.4-fold (0.13 log units) below what was measured; the range from low to high includes it.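

In this assay, cyano in place of hydrogen on the aromatic carbon ortho to a methoxy group gives a 3.8-fold higher number from compound 1 to compound 3 (0.58 log units; beyond the scatter), a modest step. Among the compounds shown here, the earlier pair changed only the methoxy group itself, so this is the first reading of a change at another place on that ring, and it shows that this carbon can carry cyano while the read-out remains an exact number rather than a limit. Nothing shown here explains the size of this step.

A single group at this carbon cannot show whether the loss is specific to cyano. On these data alone, how an amine, a carboxylic acid or a fluorine atom would read at the same carbon stays open, as does the effect of cyano on the ring of the hydroxy compound, compound 2.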